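Moving the Chlorine on the Carboxyphenyl Ring

A few compounds are considered here, and "the series" means these few. Any claim that something is new, unique, unknown or untested is made for them only; others in the source may bear on it.

Compound 1: `Cc1c(OCCCCOc2ccc(C(=O)O)cc2F)ccc(C(=O)CC(C)C)c1O`, 102 nM
Compound 2: `Cc1c(OCCCCOc2ccc(C(=O)O)cc2Cl)ccc(C(=O)CC(C)C)c1O`, 96 nM

In an assay on HEK293 cells for positive allosteric modulation of metabotropic glutamate receptor 2 (Rattus norvegicus), read by thallium flux, with a stated time of 2.5 min (on this read-out lower numbers stand for an effect already at smaller amounts and higher numbers for an effect only at larger amounts of compound), compound 1 gives 102 nM and compound 2 gives 96 nM. Compound 2 has the smaller of the two numbers, yet the step of a 1.1-fold lower number from compound 1 to compound 2 (0.03 log units; within the scatter) keeps the two within the scatter, so they stand together. Compound 3, `Cc1c(OCCCCOc2ccc(C(=O)O)c(Cl)c2)ccc(C(=O)CC(C)C)c1O`, carries the same atoms joined differently: 4-carboxy-3-chlorophenyl in place of 4-carboxy-2-chlorophenyl on an oxygen on a saturated carbon. Among the measured compounds shown here, the only measured step, from compound 1 to compound 2, exchanges one halogen for another at an unchanged position and was within the scatter; no measured pair speaks to shifting the chlorine to another position on that ring. With nothing pointing either way, the step of a 1.0-fold higher number from compound 2 to compound 3 (0.02 log units; within the scatter) in this assay is expected to stay within the scatter, though with wide uncertainty. Compound 3 is therefore estimated at 100 nM, in a range from 35 nM to 300 nM.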

Compound 3, half-maximal effective concentration: 151 nM
The estimate for compound 3 lay 1.5-fold (0.18 log units) below the measured number; measured number inside the range.
By their numbers in this assay, from the lowest: compounds 2, 1 and 3 (each within the scatter of the next).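

In this assay, among the compounds shown here, the result gives the first reading on where the chlorine stands on this ring: 4-carboxy-3-chlorophenyl in place of 4-carboxy-2-chlorophenyl yields a 1.6-fold higher number from compound 2 to compound 3 (0.20 log units; within the scatter) for this exchange of atoms with no change in their number. Against the fluorine-bearing compound, 4-carboxy-3-chlorophenyl in place of 4-carboxy-2-fluorophenyl yields a 1.5-fold higher number from compound 1 to compound 3 (0.17 log units; within the scatter) and so also stays inside the usual spread, which means that neither the halogen nor its place has yet separated any of the three compounds. No independent measurement is available to explain these numbers.

From the compounds shown here alone, whether 4-carboxy-3-fluorophenyl, or a bromine, methyl or nitrile on that ring, would stay within the scatter remains open. So does the outcome of an amide in place of the carboxylic acid, or of a longer chain on the oxygen.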